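The source may hold more compounds than are shown below. What is called first, only, known or untested is meant among the compounds shown, and "the series" means these compounds.

In a functional assay on NCI-H23 cells (Homo sapiens) for cytotoxicity, read by colorimetric assay (a lower number here means a stronger inhibitor, a higher number a weaker inhibitor), compound 3 (`O=C(NO)c1ccc(CN2C(=O)/C(=C3\Nc4ccccc4\C3=N/O)c3cc(Cl)ccc32)cc1`) gives 50 nM. Among the measured compounds shown here, compound 1 (`O=C(/C=C/c1ccc(CN2C(=O)/C(=C3\Nc4ccccc4\C3=N/O)c3cccc(Cl)c32)cc1)NO`) gives 50 nM, level with compound 3, and these two share the highest number measured so far. Compound 2 (`O=C(/C=C/c1ccc(CN2C(=O)/C(=C3\Nc4ccccc4\C3=N/O)c3cc(Cl)ccc32)cc1)NO`) gives 7 nM, a lower number than either.

The next compound, compound 4 (`Cc1ccc2c(c1)/C(=C1/Nc3ccccc3/C1=N\O)C(=O)N2Cc1ccc(C(=O)NO)cc1`), differs from compound 3 by methyl in place of chloro on an aromatic carbon of a six-membered aromatic ring of carbon only.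

For the measured compounds named here, no measured pair makes this replacement. Going by the values given here, the one measured step, a 7.1-fold higher number from compound 2 to compound 3 (0.85 log units; beyond the scatter), is hydroxycarbamoyl in place of 2-(hydroxycarbamoyl)ethenyl, a change at another place, so it sets no size for this one. Compound 1 and compound 2 carry chloro at different places on the shared core, and their two values show that the number can differ within this small set, which argues for a wide range. Neither comparison gives a direction for replacing chloro with methyl, so no shift beyond the scatter is expected in this assay, with compound 3 at 50 nM as the anchor.

The estimated step is no change at the digits printed from compound 3 to compound 4 (within the scatter). Compound 4 is expected at 50 nM, with an estimated range of 18 nM to 140 nM.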

Compound 4, half-maximal inhibitory concentration: 10 nM
Compound 4: the middle estimate sits 5.0-fold (0.70 log units) above what was measured, and the stated range ends above it.
By their numbers in this assay, from the lowest: compounds 2 and 4 (each within the scatter of the next); then compounds 1 and 3 (each within the scatter of the next).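

In this assay, the series now has a first size and direction for methyl in place of chloro on an aromatic carbon: a 5.0-fold lower number from compound 3 to compound 4 (0.70 log units; beyond the scatter). The number at this place on the shared core, meta to a fused ring and para to a fused ring, therefore responds to the choice of substituent, even though the swap exchanges one heavy atom for one heavy atom and leaves the ring, hydrogen-bond donor, hydrogen-bond acceptor and net charge counts unchanged. Nothing available here accounts for the lower number with methyl, so the observation stands without an explanation.

Going by these compounds, this reading rests on a single pair with the hydroxycarbamoyl group on the aromatic carbon, so it remains open whether the same replacement gives a step of similar size and direction alongside the 2-(hydroxycarbamoyl)ethenyl group of compound 2. On these data alone, it also remains open how hydrogen, fluoro, methoxy or an amine at this place would compare with methyl and chloro, and whether a longer alkyl chain such as ethyl would extend the step or reverse it.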